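The source may report more compounds than this note shows. Statements on the series, on what has been measured and on what is new or still open speak of the compounds shown alone.

Compound 3, `Cc1cc(C)cc(NC(=O)NCCNS(=O)(=O)c2ccc(-c3ccccc3Oc3ccc([N+](=O)[O-])c([N+](=O)[O-])c3)s2)c1`, stands in an ADME assay on HEK-293T cells (Homo sapiens) for cytotoxicity, read by CCK-8 assay, with a stated time of 48 h (on this read-out higher numbers stand for weaker inhibition and lower numbers for stronger inhibition), only at a limit of the assay, > 50000 nM. Compound 2, `O=C(NCCNS(=O)(=O)c1ccc(-c2ccccc2Oc2ccc([N+](=O)[O-])c([N+](=O)[O-])c2)s1)Nc1cc(Cl)cc(Cl)c1`, likewise reaches only a limit, > 20000 nM. Compound 1, `COc1ccc(NC(=O)NCCNS(=O)(=O)c2ccc(-c3ccccc3Oc3ccc([N+](=O)[O-])cc3)s2)cc1`, also gives a limit, > 20000 nM. Going by the values given here, the one measured step, a step that the two limits leave unreadable from compound 2 to compound 3, cannot be read, since both ends are limits; across the set two values sit at the limit of > 20000 nM in this assay, at which 2 of the 3 values shown sit, and one at the limit of > 50000 nM in this assay, at which 1 of the 3 values shown sits. Compound 4, `COc1ccc(NC(=O)NCCNS(=O)(=O)c2ccc(-c3ccccc3Oc3ccc([N+](=O)[O-])c([N+](=O)[O-])c3)s2)cc1`, differs from compound 3 by 4-methoxyphenyl in place of 3,5-dimethylphenyl on an amide-type nitrogen. Among the compounds with values here, no measured step bears on this change; compound 1 carries the same 4-methoxyphenyl group and shows no number. The expected step from compound 3 to compound 4 in this assay is therefore a number no higher from compound 3 to compound 4 (the limit leaves the size open), nothing beyond the scatter. Compound 4 is estimated at 50000 nM, between 20000 nM and 150000 nM, most likely again a limit.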

Compound 4, half-maximal inhibitory concentration: 18500 nM
Estimate against measurement, compound 4: 2.7-fold (0.43 log units) above; measured number outside the range, below it.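

In this assay, going by these compounds alone, the change on the amide-type nitrogen gives the first step with a readable floor, an at least 2.7-fold lower number from compound 3 to compound 4 (0.43 log units; beyond the scatter), and that step is a floor only since compound 3 stands at a limit. The other two comparisons give floors alone, an at least 1.0-fold lower number from compound 2 to compound 4 (0.03 log units; that floor lies within the scatter) and an at least 1.0-fold lower number from compound 1 to compound 4 (0.03 log units; that floor lies within the scatter), so neither shows an effect of its change. Nothing measured here accounts for the step.

As far as these compounds go, the true distance of compound 1, compound 2 and compound 3 from compound 4 stays open. So does the reading of an amine or a carboxylic acid in place of 4-methoxyphenyl on this nitrogen.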